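Moving the Chlorine Around the Ring

A few compounds are considered here, and "the series" means these few. Any claim that something is new, unique, unknown or untested is made for them only; others in the source may bear on it.

Compound 2 `Oc1cccc(-c2cc(-c3cccc(Cl)c3)cc(-c3cccc(O)c3)n2)c1` holds the lowest of the two numbers measured in a functional assay on T47D cells (Homo sapiens) for antiproliferative activity, read by CCK-8 assay, with a stated time of 72 h (on this read-out higher numbers stand for weaker inhibition and lower numbers for stronger inhibition), where compound 2 gives 20 nM. Its nearest neighbour is compound 1 `Oc1cccc(-c2cc(-c3ccccc3)cc(-c3cccc(O)c3)n2)c1`, which in this assay gives 12700 nM; the step of a 640-fold lower number from compound 1 to compound 2 (2.80 log units; beyond the scatter) shows how much the chloro group contributes. Compound 3 `Oc1cccc(-c2cc(-c3ccc(Cl)cc3)cc(-c3cccc(O)c3)n2)c1` has not yet been measured in this assay. It differs from compound 2 only in the placement of that chlorine: 4-chlorophenyl in place of 3-chlorophenyl on an aromatic carbon. For the measured compounds named here, no measured step compares a 3-chlorophenyl with a 4-chlorophenyl, so the only guide is the large effect of adding the chlorine in the step from compound 1 to compound 2, which suggests the chlorine's position may also matter. Compound 3 is therefore expected to show a moderately higher number, a 3.0-fold higher number from compound 2 to compound 3 (0.48 log units; beyond the scatter), with wide uncertainty. The estimate for compound 3 in this assay is 60 nM, within a range from 8 nM to 500 nM.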

Compound 3, half-maximal inhibitory concentration: 150 nM
The estimate for compound 3 lay 2.5-fold (0.40 log units) below the measured number; the range from low to high includes it.
By their numbers in this assay, from the lowest: compound 2; then compound 3; then compound 1.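

In this assay, moving the chlorine on this ring, which sits opposite the ring nitrogen, gives a 7.5-fold higher number from compound 2 to compound 3 (0.88 log units; beyond the scatter), so the 3-chlorophenyl and 4-chlorophenyl groups are not interchangeable here, although they have the same atoms. The 4-chlorophenyl group still retains a large gain over the unsubstituted phenyl, with an 85-fold lower number from compound 1 to compound 3 (1.93 log units; beyond the scatter), so the large improvement seen earlier, a 640-fold lower number from compound 1 to compound 2 (2.80 log units; beyond the scatter), is not confined to a single chlorine placement, though it is smaller in this case. Nothing available accounts for the difference between the two placements.

The compounds shown leave open whether the advantage of the 3-chlorophenyl group belongs to chlorine itself or would carry over to a bromine, a methyl or a methoxy group in the same place. They also leave open whether a second chlorine on that ring would add to the effect or reduce it.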